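Bromine on the second ring of a fused core

This account rests on a few compounds, and the source may have more. Where it says the series, first, only, none or still open, it means among the compounds named here.

For the measured compounds named here, the account begins with compound 1 `CSc1nc2ccc(C)cn2c(=N)c1S(=O)(=O)c1ccccc1`, which in an assay on HeLa cells for displacement of a labelled ligand from 5-hydroxytryptamine receptor 6 (Homo sapiens) (on this read-out higher numbers stand for weaker inhibition and lower numbers for stronger inhibition), gives 1.3 nM, the lowest of the three numbers measured so far. Compound 2 `CSc1nc2c(C)cccn2c(=N)c1S(=O)(=O)c1ccccc1`, its companion, has the same atoms joined differently; the difference between the two cores is not broken down here. In this assay compound 2 gives 3.4 nM. Compound 3 `CSc1nc2c(C)cc(Br)cn2c(=N)c1S(=O)(=O)c1ccccc1` carries the core of compound 2 with one more group, and in this assay compound 3 gives 12 nM. Going by the values given here, the one measured step of a single change is a 3.5-fold higher number from compound 2 to compound 3 (0.55 log units; beyond the scatter), the change being (bromo in place of hydrogen on an aromatic carbon).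

Compound 4 `CSc1nc2c(Br)cc(C)cn2c(=N)c1S(=O)(=O)c1ccccc1` is not yet measured. It arises from compound 1 by bromo in place of hydrogen on an aromatic carbon. The group that enters and the group that leaves are the same as in the step from compound 2 to compound 3, yet the place is not the same word for word: in compound 3 the bromo is para to a fused ring, in compound 4 it is ortho to a fused ring. It is therefore the same kind of change, not the same change. On that single precedent, the step from compound 2 to compound 3, the account expects a 3.5-fold higher number from compound 1 to compound 4 (0.54 log units; beyond the scatter), a step of about the size of a 3.5-fold higher number from compound 2 to compound 3 (0.55 log units; beyond the scatter). For compound 4 in this assay the estimate is 4.5 nM, with a range from 1.5 nM to 14 nM.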

Compound 4, half-maximal inhibitory concentration: 126 nM
The estimate for compound 4 lay 28-fold (1.45 log units) below the measured number; measured number outside the range, above it.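

In this assay the new step, a 97-fold higher number from compound 1 to compound 4 (1.99 log units; beyond the scatter), is large, and the change does not carry over at one size from one core to the other: the same change on two cores in this assay, a 3.5-fold higher number (0.55 log units; beyond the scatter) from compound 2 to compound 3 and a 97-fold higher number (1.99 log units; beyond the scatter) from compound 1 to compound 4, 27-fold (1.44 log units) apart, beyond the scatter of two such steps. Both steps run in the same direction, towards weaker inhibition, so on these two pairs the direction of the change holds while its size does not, and a step measured on one core gave no safe measure of the step on the other. What the pairs do not show is what sets the two sizes apart, since the bromo in compound 4 stands ortho to a fused ring, which is not its place in compound 3, and the methyl group also sits differently on the two cores, so place and core change together and two pairs cannot separate them.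

The compounds shown leave open whether a smaller or different group on the same aromatic carbon as the bromo of compound 4, such as chloro, methoxy or an amine, would bring a step as large as this one. They also leave open whether the same large step would appear with an ethylthio group in place of the methylthio group, or with a substituent on the phenyl ring of the sulfonyl group.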